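The compounds below may be only part of what the source reports. "The series", "measured", "known", "first", "only" and "open" are said of these compounds alone.

In a physicochemical assay for lipophilicity, read by HPLC, using the shake flask method (a lower number here means a more polar compound, a higher number a more lipophilic compound), compound 1 (`C/C(=N\C#N)N(Cc1ccccc1)Cc1ccc(Cl)nc1`) gives 2.11 and compound 2 (`CCCCN(Cc1ccc(Cl)nc1)/C(C)=N/C#N`) gives 2.13 so the two cannot be told apart. Compound 3 (`CCCN(Cc1ccc(Cl)nc1)/C(C)=N/C#N`) is still to be measured. It differs from compound 2 by hydrogen in place of methyl on a saturated chain carbon, three bonds along the chain from an amine nitrogen in the form of hydrogen in place of methyl on a saturated chain carbon, three bonds along the chain from an amine nitrogen, which reads as butyl to propyl.

Within the data shown here, the one measured step is a number 0.02 log units higher from compound 1 to compound 2 (within the scatter) and it has propyl in place of phenyl on a saturated chain carbon bound to an amine nitrogen. Among the measured compounds shown here, that step bears only loosely on the change at hand: it exchanges a different group, and no measured pair yet differs in chain length alone.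

Starting from compound 2 at 2.13 the structural change alone leads to the expectation of a lower number in this assay and of a size beyond the scatter. The expected step is a number 0.43 log units lower from compound 2 to compound 3 (beyond the scatter) on this reading. For compound 3 the estimated value is 1.7 with an expected range from 1.45 to 1.95 once measured.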

Compound 3, partition coefficient: 1.62
Compound 3: the middle estimate sits 0.08 log units above what was measured; low and high end bracket the measured number.
By their numbers in this assay, from the lowest: compound 3; then compounds 1 and 2 (each within the scatter of the next).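

Among these compounds, in the terms of this assay, the change from butyl to propyl is the first difference in chain length alone, and it gives a clear step (a number 0.51 log units lower from compound 2 to compound 3 (beyond the scatter)), so the read-out does respond to hydrogen in place of methyl at this place, on a saturated chain carbon, three bonds along the chain from an amine nitrogen. The match between the phenyl-bearing compound and the butyl chain (a number 0.02 log units higher from compound 1 to compound 2 (within the scatter)) therefore does not carry over to the propyl chain, which separates from the phenyl-bearing compound by a similar margin (a number 0.49 log units lower from compound 1 to compound 3 (beyond the scatter)). No measurement available here bears on the reason for either step.

As far as these compounds go, with only butyl and propyl to compare, a single chain-length step is known, and it remains open whether an ethyl, a methyl or a longer chain such as pentyl would continue it in even steps. Also open, from the compounds shown here alone, is how the read-out would respond to a branched chain such as isobutyl, or to a hydroxyl or an ether oxygen placed in the chain at this same position.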